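Swapping 3-iodophenyl for 4-carboxycyclohexyl on the shared core

This account rests on a few compounds, and the source may have more. Where it says the series, first, only, none or still open, it means among the compounds named here.

Among the compounds with values here, in a functional assay on MCF7 cells (Homo sapiens) for cytotoxicity, read by MTT assay (a lower number here means a stronger inhibitor, a higher number a weaker inhibitor), compound 1 `Oc1ccc(CN(Cc2ccccc2)Cc2ccc(O)c3ncccc23)c2cccnc12` gives 97 nM, and compound 2 `Oc1ccc(CN(Cc2cccc(I)c2)Cc2ccc(O)c3ncccc23)c2cccnc12` gives 374 nM, the higher of the two numbers measured so far. Compound 3 `O=C(O)C1CCC(CN(Cc2ccc(O)c3ncccc23)Cc2ccc(O)c3ncccc23)CC1` has not yet been measured. It departs from compound 2 by 4-carboxycyclohexyl in place of 3-iodophenyl on a saturated chain carbon bound to an amine nitrogen, with 4-carboxycyclohexyl in place of 3-iodophenyl on a saturated chain carbon bound to an amine nitrogen. Within the data shown here, only one measured step bears on this change, and only loosely: a 3.9-fold higher number from compound 1 to compound 2 (0.59 log units; beyond the scatter), a modest move beyond the scatter, with iodo in place of hydrogen on an aromatic carbon. Among the measured compounds shown here, no measured compound carries a carboxy group or a non-aromatic ring at this place, so the direction is a judgement and the uncertainty is wide. The expected change is a 2.4-fold higher number from compound 2 to compound 3 (0.38 log units; beyond the scatter), a modest move toward a higher number. For compound 3 the estimated value is 900 nM, with an expected range of 200 nM to 4000 nM.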

Compound 3, half-maximal inhibitory concentration: 9460 nM
The estimate for compound 3 lay 11-fold (1.02 log units) below the measured number; the whole stated range lies below it.
By their numbers in this assay, from the lowest: compound 1; then compound 2; then compound 3.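

In this assay the place on a saturated chain carbon bound to an amine nitrogen proves far less forgiving than the earlier pair suggested: 4-carboxycyclohexyl in place of 3-iodophenyl brings a 25-fold higher number from compound 2 to compound 3 (1.40 log units; beyond the scatter) and so outruns the modest 3.9-fold higher number from compound 1 to compound 2 (0.59 log units; beyond the scatter) seen with iodo on the aromatic ring. Measured against the plain phenyl of the first compound, the same place shows a 98-fold higher number from compound 1 to compound 3 (1.99 log units; beyond the scatter) and this is the largest step in the set, so a change of the whole ring matters here much more than the one substituent did. Nothing available accounts for the size of this loss.

The compounds shown leave open whether the loss follows the non-aromatic ring or the carboxy group, as the two enter together. A plain cyclohexyl ring and a phenyl ring bearing a carboxylic acid would separate them.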